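Sulfonyl aryl series: expectation for compound 4

The source may hold more compounds than are shown below. What is called first, only, known or untested is meant among the compounds shown, and "the series" means these compounds.

In a functional assay on DLD-1 cells (Homo sapiens) for antiproliferative activity, read by CellTiter-Glo, with a stated time of 72 h (a higher number here means a weaker inhibitor, a lower number a stronger inhibitor), compound 3 `CC1CCN(C2CCN(S(=O)(=O)c3ccc(Cl)cc3Cl)CC2)CC1` gives 1 nM, the lowest of the two numbers shown; compound 2 `Cc1nc(Cl)sc1S(=O)(=O)N1CCC(N2CCC(C)CC2)CC1` gives 1.6 nM, and the step of a 1.6-fold lower number from compound 2 to compound 3 (0.20 log units; within the scatter) lies within the scatter. Compound 1 `CC1CCN(C2CCN(S(=O)(=O)c3cccnc3Cl)CC2)CC1` reaches only a limit of the assay, > 5000 nM. The change to compound 4 `CC1CCN(C2CCN(S(=O)(=O)c3cccnc3F)CC2)CC1` is 2-fluoropyridin-3-yl in place of 2,4-dichlorophenyl on a sulfonyl sulfur. The measured step that bears on it is an at least 5000-fold lower number from compound 1 to compound 3 (3.69 log units; beyond the scatter), which runs the opposite way, from a pyridinyl to the dichlorophenyl; an at least 3100-fold lower number from compound 1 to compound 2 (3.49 log units; beyond the scatter) is of like size. From the compounds shown here alone, since compound 1 sits at a limit (the limit of > 5000 nM in this assay, at which 1 of the 3 values shown sits), the full extent of that step is unknown. A large rise in this assay is therefore expected for compound 4, about a 4000-fold higher number from compound 3 to compound 4 (3.60 log units; beyond the scatter). Compound 4 is estimated at 4000 nM, between 500 nM and 20000 nM.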

Compound 4, half-maximal inhibitory concentration: > 5000 nM
Compound 4: no number, only a limit; the forecaster's own chance of this, stated with the estimate: 50%; middle value at least 1.2-fold (0.09 log units) away from the limit.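

With 2-fluoropyridin-3-yl on the sulfonyl sulfur, the loss seen with the chloropyridinyl compound 1 recurs: an at least 5000-fold higher number from compound 3 to compound 4 (3.69 log units; beyond the scatter) and an at least 3100-fold higher number from compound 2 to compound 4 (3.49 log units; beyond the scatter). Among the compounds shown, both pyridinyl groups therefore go with a loss, and changing the halogen on this ring restores no measurable activity. Compound 1 and compound 4 both stand at a limit, so fluoro in place of chloro cannot be read in this assay: the limit of > 5000 nM in this assay, at which 2 of the 4 values shown sit.

Still open, from the compounds shown here alone, is how far either compound lies past that limit. Also open, going by these compounds, is whether a pyridinyl bearing a methoxy group or an amine instead of the halogen would regain activity.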